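Fluoro for chloro on the 2-chloro-4-fluorophenyl group

The source may report more compounds than this note shows. Statements on the series, on what has been measured and on what is new or still open speak of the compounds shown alone.

Measured so far in a functional assay on ACHN cells (Homo sapiens); on this read-out higher numbers stand for weaker inhibition of growth and lower numbers for stronger inhibition of growth:
- compound 1 `O=S(=O)(/C=C/c1ccc(F)cc1F)Cc1ccc(Nc2ncnc3ccccc23)cc1` gives 31000 nM
- compound 2 `O=S(=O)(/C=C/c1ccc(Cl)cc1Cl)Cc1ccc(Nc2ncnc3cc(Cl)ccc23)cc1` gives 8000 nM
- compound 3 `O=S(=O)(/C=C/c1ccc(F)cc1Cl)Cc1ccc(Nc2ncnc3cc(Cl)ccc23)cc1` gives 17000 nM

Compound 3 sits within the scatter of compound 1 and above compound 2 by more than the scatter. Compound 4 `O=S(=O)(/C=C/c1ccc(F)cc1F)Cc1ccc(Nc2ncnc3cc(Cl)ccc23)cc1` follows from compound 3 by fluoro in place of chloro on an aromatic carbon and carries 2,4-difluorophenyl. Within the data shown here, the one measured step of this kind is a 2.1-fold higher number from compound 2 to compound 3 (0.33 log units; beyond the scatter) and is modest. Compound 1 at 31000 nM also carries 2,4-difluorophenyl, on a different core. A step of similar size and the same direction is therefore expected in this assay as a 1.8-fold higher number from compound 3 to compound 4 (0.25 log units; within the scatter) for this change. Compound 4 is expected at 30000 nM within an estimated range of 14000 nM to 60000 nM for now.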

Compound 4, concentration for 50% growth inhibition: > 100000 nM
Compound 4 ended at the assay's limit; the forecaster's own chance of this, stated with the estimate: 10%; at least 3.3-fold (0.52 log units) between middle value and limit.
By their numbers in this assay, from the lowest: compound 2; then compounds 3 and 1 (each within the scatter of the next). At a limit, above all of these: compound 4.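

In this assay compound 4 gives > 100000 nM, a limit of the assay and not a number: the limit of > 100000 nM in this assay, at which 1 of the 4 values shown sits.

Fluoro in place of chloro ortho to a large group, on a ring already carrying the other halogen, gives an at least 5.8-fold higher number from compound 3 to compound 4 (0.76 log units; beyond the scatter), and 2,4-difluorophenyl in place of 2,4-dichlorophenyl gives an at least 12-fold higher number from compound 2 to compound 4 (1.09 log units; beyond the scatter). With 2,4-difluorophenyl held constant, chloro in place of hydrogen on the core brings no gain in growth inhibition, giving an at least 3.2-fold higher number from compound 1 to compound 4 (0.50 log units; beyond the scatter).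

From the compounds shown here alone, the true position of compound 4 beyond the limit remains open. So does how a methyl or methoxy group would read at this place.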